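A few compounds are considered here, and "the series" means these few. Any claim that something is new, unique, unknown or untested is made for them only; others in the source may bear on it.

Measured in a functional assay on brain (Rattus norvegicus, strain Wistar) for inhibition; a lower number here means a stronger inhibitor, a higher number a weaker inhibitor:
- compound 1 `Cc1[nH]c(=O)n(C2CCCCC2)c1-c1ccccc1`: 47600 nM
- compound 2 `CCCCOc1ccc(-c2c(C)[nH]c(=O)n2C2CCCCC2)cc1`: 13900 nM
- compound 3 `CCCCCCCOc1ccc(-c2c(C)[nH]c(=O)n2C2CCCCC2)cc1`: 11600 nM

Compound 3 shares the low end of this short series with compound 2, and both lie clearly under compound 1. Adding a butoxy group to the plain core gives a 3.4-fold lower number from compound 1 to compound 2 (0.53 log units; beyond the scatter), and adding a heptyloxy group gives a 4.1-fold lower number from compound 1 to compound 3 (0.61 log units; beyond the scatter). Both steps are modest but beyond the scatter. Lengthening the chain gives a 1.2-fold lower number from compound 2 to compound 3 (0.08 log units; within the scatter), which is within the scatter.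

Compound 4 `CCCCCCCCc1ccc(-c2c(C)[nH]c(=O)n2C2CCCCC2)cc1` has octyl in place of heptyloxy on an aromatic carbon, para to a large group (octyl in place of heptyloxy on an aromatic carbon). Among the compounds with values here, no measured pair shows what this exchange does, so the expectation rests on indirect evidence. The closest guide is the chain lengthening, where compound 3 at 11600 nM stayed within the scatter of compound 2. From the compounds shown here alone, the loss of the chain's oxygen remains untested, which keeps the range wide. In this assay, no shift beyond the scatter is expected in either direction. The expected change is a 1.2-fold lower number from compound 3 to compound 4 (0.06 log units; within the scatter). The estimated value for compound 4 is 10000 nM, with an expected range of 4000 nM to 25000 nM.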

Compound 4, half-maximal inhibitory concentration: 10300 nM
Estimate against measurement, compound 4: 1.0-fold (0.01 log units) below, and the stated range covers the measured number.
By their numbers in this assay, from the lowest: compounds 4, 3 and 2 (each within the scatter of the next); then compound 1.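

In this assay, putting octyl in place of heptyloxy on the aromatic carbon keeps the count of 8 heavy atoms but removes the chain's oxygen and its one hydrogen-bond acceptor, and the step stays within the scatter (a 1.1-fold lower number from compound 3 to compound 4 (0.05 log units; within the scatter)). Octyl also lies within the scatter of the shorter butoxy group (a 1.3-fold lower number from compound 2 to compound 4 (0.13 log units; within the scatter)), yet it keeps a modest step beyond the scatter from the unsubstituted core (a 4.6-fold lower number from compound 1 to compound 4 (0.66 log units; beyond the scatter)), so among these compounds the step away from hydrogen at this position does not depend on an oxygen in the chain. No supporting evidence is available to explain this result.

The compounds shown leave open whether a group shorter than butoxy, such as methoxy or methyl, already gives a step of this size from compound 1, and how a chain ending in an amine or a carboxylic acid would compare with octyl. From the compounds shown here alone, it also remains open how a fluorine or a phenyl ring at this same place would read against these chains.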